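The source may hold more compounds than are shown below. What is called first, only, known or untested is meant among the compounds shown, and "the series" means these compounds.

In an ADME assay on L02 cells (Homo sapiens) for cytotoxicity, read by MTT assay, with a stated time of 72 h (on this read-out lower numbers stand for stronger inhibition and higher numbers for weaker inhibition), compound 1 (`C=CC(=O)Nc1cc2c(Nc3ccc(F)c(Cl)c3)ncnc2cc1OCc1cn(CCC(=O)NO)nn1`) gives > 25000 nM as a limit, not a number. Compound 2 (`C=CC(=O)Nc1cc2c(Nc3ccc(F)c(Cl)c3)ncnc2cc1OCc1cn(CCCC(=O)NO)nn1`) gives > 25000 nM as a limit too. Compound 3 (`C=CC(=O)Nc1cc2c(Nc3ccc(OCc4cccc(F)c4)c(Cl)c3)ncnc2cc1OCc1cn(CCC(=O)NO)nn1`) gives > 25000 nM as a limit too. For the measured compounds named here, compound 1 therefore has no number to stand on, and the series so far is the limit of > 25000 nM in this assay, at which 3 of the 3 values shown sit, and nothing finer.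

Compound 4 (`C=CC(=O)Nc1cc2c(Nc3cccc(Cl)c3F)ncnc2cc1OCc1cn(CCC(=O)NO)nn1`) carries 3-chloro-2-fluorophenyl in place of 3-chloro-4-fluorophenyl on a nitrogen on an aromatic ring. Only a step that the two limits leave unreadable from compound 1 to compound 3 touches that phenyl group while a step that the two limits leave unreadable from compound 1 to compound 2 lies on the chain, and neither gives a size to carry over. With compound 1 and both of its measured neighbours at the same limit, in this assay no step beyond the scatter is expected in either direction. The estimated change is a step that the limit leaves unreadable from compound 1 to compound 4 and no more. Compound 4 is estimated at 28000 nM with a range of 12000 nM to 60000 nM and is expected most likely to return only a limit again.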

Compound 4, half-maximal inhibitory concentration: > 25000 nM
Compound 4: only a limit was reported; the forecaster's own chance of this, stated with the estimate: 80%; the middle value lies beyond the limit too.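

In this assay, for the compounds shown here, compound 4 gives > 25000 nM, a limit and not a number, so no step from compound 1 to compound 4 can be read. Left open is how compound 1, compound 2, compound 3 and compound 4 truly compare, since all rest on one value: the limit of > 25000 nM in this assay, at which 4 of the 4 values shown sit.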